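Chloro removal on the aryl urea of a diaryl ether series

A few compounds are considered here, and "the series" means these few. Any claim that something is new, unique, unknown or untested is made for them only; others in the source may bear on it.

Measured compounds:
compound 1 `Cn1ncnc1-c1cc(Oc2ccc(NC(=O)Nc3cccc(C(F)(F)F)c3)cc2F)ccn1` 9680 nM
compound 2 `CN(C)CCCn1cnnc1-c1cc(Oc2ccc(NC(=O)Nc3ccc(Cl)c(C(F)(F)F)c3)cc2F)ccn1` 7880 nM

In a functional assay on MDA-MB-231 cells (Homo sapiens) for antiproliferative activity, read by MTT assay, with a stated time of 72 h (a lower number here means a stronger inhibitor, a higher number a weaker inhibitor), compound 2 gives 7880 nM and compound 1 gives 9680 nM; the two numbers sit within the scatter of each other, so no order between them can be read. Compound 3 `CN(C)CCCn1cnnc1-c1cc(Oc2ccc(NC(=O)Nc3cccc(C(F)(F)F)c3)cc2F)ccn1` is not yet measured; it differs from compound 2 by hydrogen in place of chloro on an aromatic carbon. Within the data shown here, no measured step of this kind exists. The step from compound 2 to compound 3 in this assay is expected to be small, at most a slight weakening, and likely not beyond the scatter, namely a 1.3-fold higher number from compound 2 to compound 3 (0.10 log units; within the scatter). Compound 3 is therefore estimated at 10000 nM, with a range of 4000 nM to 25000 nM.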

Compound 3, half-maximal inhibitory concentration: 13300 nM
Estimate against measurement, compound 3: 1.3-fold (0.12 log units) below; the measured number falls inside the stated range.
By their numbers in this assay, from the lowest: compounds 2, 1 and 3 (each within the scatter of the next).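

In this assay, among these compounds, the 4-chloro-3-(trifluoromethyl)phenyl to 3-(trifluoromethyl)phenyl change gives the first direct reading at this position (a 1.7-fold higher number from compound 2 to compound 3 (0.23 log units; within the scatter)), so no effect of the chloro can be read. With that aryl group held, 4-(3-(dimethylamino)propyl)-4H-1,2,4-triazol-3-yl in place of 1-methyl-1H-1,2,4-triazol-5-yl also shows no readable effect (a 1.4-fold higher number from compound 1 to compound 3 (0.14 log units; within the scatter)). Nothing available explains either step.

As far as these compounds go, whether a fluoro, methoxy or nitrile group at this position would move the number beyond the scatter stays open. So does the effect of a morpholine in place of the dimethylamino group, or of a longer chain.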